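Sulfonamide to Amide Swap on a Fluorophenyl Core

The compounds below may be only part of what the source reports. "The series", "measured", "known", "first", "only" and "open" are said of these compounds alone.

Measured compounds:
compound 1 `O=S(=O)(NCCCNc1nccc(-c2c(-c3cccc(F)c3)nc3sccn23)n1)c1ccccc1` — 6600 nM
compound 2 `O=C(NCCCNc1nccc(-c2c(-c3cccc(F)c3)nc3sccn23)n1)c1ccc(Cl)cc1` — 13700 nM
compound 3 `O=S(=O)(NCCCNc1nccc(-c2c(-c3cccc(F)c3)nc3sccn23)n1)c1ccc(Cl)cc1` — 5900 nM

In a functional assay on A-375 cells (Homo sapiens) for cytotoxicity, read by MTT assay (on this read-out lower numbers stand for stronger inhibition and higher numbers for weaker inhibition), compound 3 gives the lowest of the three numbers; compound 1 sits within the scatter of it, while compound 2 stands apart, as a 2.3-fold lower number from compound 2 to compound 3 (0.37 log units; beyond the scatter) shows. Compound 4 `Cc1ccc(C(=O)NCCNc2nccc(-c3c(-c4cccc(F)c4)nc4sccn34)n2)cc1` differs from compound 3 by ((4-methylphenyl)carbonyl)amino in place of (((4-chlorophenyl)sulfonyl)amino)methyl on a saturated chain carbon, two bonds along the chain from a nitrogen on an aromatic ring. The sulfonyl-to-carbonyl steps bear on this: a 2.3-fold lower number from compound 2 to compound 3 (0.37 log units; beyond the scatter) and a 2.1-fold higher number from compound 1 to compound 2 (0.32 log units; beyond the scatter) both place the carbonyl compound at the higher number. Among the measured compounds shown here, the exchange also touches the chain and the ring substituent, parts for which no step is measured. Compound 4 is therefore expected to show a 2.2-fold higher number from compound 3 to compound 4 (0.34 log units; beyond the scatter) in this assay. Compound 4 is estimated at 13000 nM, with a range from 5000 nM to 35000 nM.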

Compound 4, half-maximal inhibitory concentration: 5880 nM
For compound 4 the middle estimate is 2.2-fold (0.34 log units) above the measured one, and the stated range covers the measured number.
By their numbers in this assay, from the lowest: compounds 4, 3 and 1 (each within the scatter of the next); then compound 2.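

In this assay a carbonyl compound no longer stands apart from the sulfonyl compounds, with a 1.0-fold lower number from compound 3 to compound 4 (0.00 log units; within the scatter) and a 1.1-fold lower number from compound 1 to compound 4 (0.05 log units; within the scatter) on this exchange. Compound 2, the other carbonyl compound, remains apart, with a 2.3-fold lower number from compound 2 to compound 4 (0.37 log units; beyond the scatter) where the ((4-methylphenyl)carbonyl)amino group enters. No measurement at hand explains this result. The chain and the ring substituent change together in compound 4, so their separate shares cannot be told apart. From the compounds shown here alone, how a longer chain, or an amine in place of the carbonyl, would read remains open.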